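Trimming an Ethyl Group to a Methyl

This account rests on a few compounds, and the source may have more. Where it says the series, first, only, none or still open, it means among the compounds named here.

In a functional assay on NCI-H1975 cells (Homo sapiens) for inhibition, read by sulforhodamine B assay, with a stated time of 48 h (a lower number here means a stronger inhibitor of growth, a higher number a weaker inhibitor of growth), compound 3 `CCN(C(=O)c1cc(C(C)C)c(O)cc1O)c1cccc(NC(=O)CCCCCCC(=O)NO)c1` gives 940 nM and compound 2 `CC(C)c1cc(C(=O)N(C)c2ccc(NC(=O)CCCCCCC(=O)NO)cc2)c(O)cc1O` gives 690 nM, two values within the scatter of each other. For compound 1 `CC(C)c1cc(C(=O)Nc2cccc(NC(=O)CCCCCCC(=O)NO)c2)c(O)cc1O`, > 10000 nM is a limit, not a number.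

Compound 4 `CC(C)c1cc(C(=O)N(C)c2cccc(NC(=O)CCCCCCC(=O)NO)c2)c(O)cc1O` trims the ethyl of compound 3 to methyl: hydrogen in place of methyl on a saturated chain carbon bound to an amide-type nitrogen. Within the data shown here, the one measured step at this nitrogen, an at least 10-fold lower number from compound 1 to compound 3 (1.02 log units; beyond the scatter), is large, but it removes the whole group, whereas compound 4 keeps one there. Compound 2, also carrying methyl on that nitrogen, gives 690 nM. No change beyond the scatter is therefore expected in this assay. The expected change is a 1.2-fold lower number from compound 3 to compound 4 (0.07 log units; within the scatter). Compound 4 is estimated at 800 nM, with an expected range of 300 nM to 2500 nM.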

Compound 4, concentration for 50% growth inhibition: 1660 nM
For compound 4 the middle estimate is 2.1-fold (0.32 log units) below the measured one, and the stated range covers the measured number.
By their numbers in this assay, from the lowest: compounds 2, 3 and 4 (each within the scatter of the next, the first and the last beyond it). At a limit, above all of these: compound 1.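

Ethyl and methyl on this amide-type nitrogen cannot be told apart in this assay, where the step is a 1.8-fold higher number from compound 3 to compound 4 (0.25 log units; within the scatter). The single carbon of methyl already separates compound 4 clearly from the compound with the amide hydrogen, with an at least 6.0-fold lower number from compound 1 to compound 4 (0.77 log units; beyond the scatter). That step gives only a bound, because the value for compound 1 is a limit: the limit of > 10000 nM in this assay, at which 1 of the 4 values shown sits.

Going by these compounds, what remains open is how a longer chain, such as propyl or butyl, would read on this nitrogen. On these data alone, a chain ending in an amine or a carboxylic acid is equally open.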